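The source may report more compounds than this note shows. Statements on the series, on what has been measured and on what is new or still open speak of the compounds shown alone.

Compound 1, whose structure is `COCC(=O)N(Cc1ccc(OC)c(O)c1)c1cc(OC)c(OC)c(OC)c1`, was tested in a functional assay on HCT-116 cells (Homo sapiens) for inhibition, read by MTT assay, with a stated time of 48 h (a higher number here means a weaker inhibitor, a lower number a stronger inhibitor), where compound 1 gives 230 nM. Of the two numbers at hand it is the lowest. The only companion, compound 2, with structure `COc1ccc(CNc2cc(OC)c(OC)c(OC)c2)cc1Br`, gives in this assay a far higher number, 48100 nM, and that gap lies well beyond the scatter. For the measured compounds named here, no single-point step between measured compounds exists, so there is no measured step to lean on for the next compound.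

Compound 3, with structure `COc1ccc(CN(C(=O)C[Se]C#N)c2cc(OC)c(OC)c(OC)c2)cc1O`, differs from compound 1 in one spot: a group of 3 heavy atoms (1 carbon, 1 nitrogen, 1 selenium; no ring) in place of a group of 2 heavy atoms (1 carbon, 1 oxygen; no ring), on a saturated chain carbon bound to a carbonyl carbon. Since nothing measured speaks to this exchange, only a small move is expected, estimated as a 1.4-fold lower number from compound 1 to compound 3 (0.16 log units; within the scatter), likely inside the scatter and, if anywhere, toward a lower number. For compound 3 the estimated result is 160 nM, with a range from 40 nM to 650 nM.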

Compound 3, half-maximal inhibitory concentration: 310 nM
Compound 3: the middle estimate sits 1.9-fold (0.29 log units) below what was measured; low and high end bracket the measured number.
By their numbers in this assay, from the lowest: compounds 1 and 3 (each within the scatter of the next); then compound 2.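

At the saturated chain carbon bound to a carbonyl carbon, replacing methoxy with the group of 3 heavy atoms, which holds selenium and a triple bond, gives a 1.3-fold higher number from compound 1 to compound 3 (0.13 log units; within the scatter) in this assay. For the compounds shown here, this is the first measured exchange at this place, and it shows that two quite different groups can sit there without the numbers parting beyond the scatter, so this assay does not separate compound 1 from compound 3. No available evidence explains this result.

Going by these compounds, with only these two groups compared at this place, it remains open how a hydroxyl group, an amine, a longer chain or a thiocyanate group would read there. One exchange also cannot show whether selenium, the nitrile or the two together shape the value of compound 3.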